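The compounds below may be only part of what the source reports. "The series", "measured", "known", "first", "only" and "open" are said of these compounds alone.

Compound 2 `COc1cc(Cl)cc(-c2nn(-c3cccc(NC(=O)Nc4cccc(C(F)(F)F)c4)c3)cc2-c2ccncc2)c1` gives the lowest of the two numbers in a functional assay on A549 cells (Homo sapiens) for inhibition, read by sulforhodamine B assay, with a stated time of 48 h, tested at 10 uM (on this read-out higher numbers stand for a weaker effect at the one concentration tested and lower numbers for a stronger effect), namely 8.08%. In this assay compound 1 `COc1cc(Cl)cc(-c2nn(-c3cccc(NC(=O)c4ccc(Cl)c(Cl)c4)c3)cc2-c2ccncc2)c1` gives 59.7%. Going by the values given here, the only measured step, a number 51.6 percentage points lower from compound 1 to compound 2 (beyond the scatter), changed two things at once, the group on the carbonyl carbon and the ring attached to it, so it bears on the present change only in part. Compound 3 `COc1cc(Cl)cc(-c2nn(-c3cccc(NC(=O)c4cccc(C(F)(F)F)c4)c3)cc2-c2ccncc2)c1` differs from compound 2 by 3-(trifluoromethyl)phenyl in place of (3-(trifluoromethyl)phenyl)amino on a carbonyl carbon. Among the compounds with values here, compound 3 thus keeps the ring of compound 2 together with the carbonyl arrangement of compound 1, and no measured pair separates the effect of these two parts. The analyst therefore expects compound 3 to land between the two measured numbers, with an upward step of a number 26.9 percentage points higher from compound 2 to compound 3 (beyond the scatter), smaller than the step just recalled but beyond the scatter. The estimate for compound 3 in this assay is 35%, within 10% to 70%.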

Compound 3, a percentage reported as activity, at one concentration (the size of the read-out at that concentration, not a potency): 39.1%
For compound 3 the middle estimate is 4.1 percentage points below the measured one; low and high end bracket the measured number.
By their numbers in this assay, from the lowest: compound 2; then compound 3; then compound 1.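

With the ring held constant, the change on the carbonyl carbon alone gives a number 31 percentage points higher from compound 2 to compound 3 (beyond the scatter) in this assay, so the amino link of compound 2 matters in its own right at this position. Going by these compounds alone, with the amide-type link held constant, the ring change alone gives a number 20.6 percentage points lower from compound 1 to compound 3 (beyond the scatter), so the 3-(trifluoromethyl)phenyl ring also counts, and the two parts that changed together in the earlier step can now be seen separately, the first step large and the second modest. Nothing available explains either step.

Whether (3,4-dichlorophenyl)amino on the carbonyl carbon would also give a lower number than compound 1 remains open, so the two parts cannot yet be shown to add up. Going by these compounds, it is also open how a nitrile in place of the trifluoromethyl group on this ring would read at the one concentration tested.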